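The source may report more compounds than this note shows. Statements on the series, on what has been measured and on what is new or still open speak of the compounds shown alone.

Compound 3 `O=C(Nc1cccc(OCc2cn(-c3ccccc3F)nn2)c1)Nc1ccc(Cl)c(C(F)(F)F)c1` gives 1520 nM in a functional assay on HepG2 cells (Homo sapiens) for inhibition, read by MTT assay, with a stated time of 72 h; on this read-out lower numbers stand for stronger inhibition and higher numbers for weaker inhibition. Of the three numbers measured, that of compound 3 is the lowest, though compound 2 `CC(C)c1ccc(-n2cc(COc3cccc(NC(=O)Nc4ccc(Cl)c(C(F)(F)F)c4)c3)nn2)cc1`, which gives 2470 nM, lies within the scatter of it; compound 1 `CCc1ccccc1-n1cc(COc2cccc(NC(=O)Nc3ccc(Cl)c(C(F)(F)F)c3)c2)nn1` gives 3530 nM, and the step of a 2.3-fold lower number from compound 1 to compound 3 (0.37 log units; beyond the scatter) is modest. Compound 4 `O=C(Nc1cccc(OCc2cn(-c3ccc(C(F)(F)F)cc3)nn2)c1)Nc1ccc(Cl)c(C(F)(F)F)c1` differs from compound 3 in one place: 4-(trifluoromethyl)phenyl in place of 2-fluorophenyl on an aromatic nitrogen. The measured steps that bear on this change all alter the group carried on the same aromatic nitrogen. For the measured compounds named here, the step of a 1.4-fold lower number from compound 1 to compound 2 (0.16 log units; within the scatter) and the step of a 1.6-fold lower number from compound 2 to compound 3 (0.21 log units; within the scatter) both stay within the scatter, and only the step of a 2.3-fold lower number from compound 1 to compound 3 (0.37 log units; beyond the scatter) reaches a modest size, so the group on this nitrogen has so far moved the numbers only a little. The expected step is therefore a 1.3-fold higher number from compound 3 to compound 4 (0.12 log units; within the scatter), nothing beyond the scatter in either direction. Compound 4 is estimated at 2000 nM, with a range from 900 nM to 4500 nM.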

Compound 4, half-maximal inhibitory concentration: 1800 nM
Estimate against measurement, compound 4: 1.1-fold (0.05 log units) above; low and high end bracket the measured number.
By their numbers in this assay, from the lowest: compounds 3, 4, 2 and 1 (each within the scatter of the next, the first and the last beyond it).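

Carrying 4-(trifluoromethyl)phenyl on the aromatic nitrogen keeps the number in this assay within the scatter of all three earlier compounds, with the step of a 1.2-fold higher number from compound 3 to compound 4 (0.07 log units; within the scatter), the step of a 1.4-fold lower number from compound 2 to compound 4 (0.14 log units; within the scatter) and the step of a 2.0-fold lower number from compound 1 to compound 4 (0.29 log units; within the scatter). Compound 1 thus lies within the scatter of compound 4 although it lies beyond the scatter of compound 3, so the larger group, with 10 heavy atoms against 7 in 2-fluorophenyl, brings no step beyond the scatter. Nothing available explains why these groups give such close numbers.

On these data alone, whether an amine, a carboxylic acid or a longer chain on the phenyl ring would move the number further remains open. So does the effect of replacing the phenyl ring on the nitrogen with a simple alkyl chain, or of changing the shared core.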